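This account rests on a few compounds, and the source may have more. Where it says the series, first, only, none or still open, it means among the compounds named here.

Measured so far:

compound 1, `CCCCNc1nc(N)nc(C)c1CCCCc1ccccc1`: 857 nM
compound 2, `CCCCNc1nc(N)nc(C)c1CCc1ccccc1`: 1190 nM
compound 3, `CCCCNc1nc(N)nc(C)c1CCCn1ccc2ccccc21`: 1100 nM

In an assay on HEK293 cells for agonist activity at Toll-like receptor 8 (Homo sapiens), read by spectrophotometry (a lower number here means that less compound is needed, a higher number that more compound is needed for the effect), compound 2 gives the largest of the three numbers, yet its gap to compound 3 and its gap to compound 1 both lie within the usual scatter of this assay, so the three compounds read as much alike. Going by the values given here, none of them differs from another in a single place, so no clean step between measured compounds can be drawn here.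

Compound 4, `CCCCNc1nc(N)nc(C)c1CCCN(CC)CC`, has not yet been measured. It differs from compound 2 in one place: (diethylamino)methyl in place of phenyl on a saturated chain carbon, two bonds along the chain from an aromatic carbon

Among the compounds with values here, nothing among the measured compounds tells how this assay answers such an exchange; the three measured compounds all keep an aromatic ring at the end of the chain, and compound 4 is the first without one. The expectation therefore rests on little: compound 4 is estimated to give a somewhat larger number than compound 2, a step of a 1.8-fold higher number from compound 2 to compound 4 (0.27 log units; within the scatter) that may still fall within the scatter. For compound 4 the estimate is 2200 nM, with a range from 600 nM to 8000 nM.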

Compound 4, half-maximal effective concentration: 254 nM
Estimate against measurement, compound 4: 8.7-fold (0.94 log units) above, outside the stated range (below it).
By their numbers in this assay, from the lowest: compound 4; then compounds 1, 3 and 2 (each within the scatter of the next).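

In this assay, an aromatic ring at the end of the chain turns out not to be required: (diethylamino)methyl in place of phenyl, on a saturated chain carbon two bonds along the chain from an aromatic carbon, gives a 4.7-fold lower number from compound 2 to compound 4 (0.67 log units; beyond the scatter), a step beyond the scatter. Described as diethylamino in place of benzyl, three bonds along the chain from an aromatic carbon, the change gives a 3.4-fold lower number from compound 1 to compound 4 (0.53 log units; beyond the scatter), also beyond the scatter, so this end of the chain can move the number even though the three compounds ending in an aromatic ring read alike. No measurement shown here explains why the number falls with this exchange.

The compounds shown leave open whether the lower number goes with the nitrogen of the diethylamino group or simply with the loss of the aromatic ring, and a cyclohexyl group at the chain end, a carbon ring without nitrogen, would help separate the two. Also open, from the compounds shown here alone, is how the number would respond to a smaller amine such as dimethylamino, to a piperidine ring, or to a longer chain carrying the amine.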